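The source may hold more compounds than are shown below. What is called first, only, known or untested is meant among the compounds shown, and "the series" means these compounds.

Measured in an ADME assay on microsomes from liver (Rattus norvegicus) for metabolic stability, read by LC-MS, with a stated time of 30 min, tested at 0.1 uM; on this read-out higher numbers stand for a more stable compound and lower numbers for a less stable compound:
compound 1 `FC(F)(F)Oc1ccc(-c2nc3cnc(Nc4ccccn4)cc3[nH]2)cc1`: 61%
compound 2 `COc1cccnc1Nc1cc2[nH]c(-c3cccc(C(F)(F)F)c3)nc2cn1`: 83%

Compound 2 holds the higher of the two numbers in this assay, and the gap down to compound 1 lies beyond the usual scatter. These two compounds differ in more than one place, so that gap cannot be tied to a single change.

Compound 3 `FC(F)(F)c1cccc(-c2nc3cnc(Nc4ccncn4)cc3[nH]2)c1`, not yet measured, keeps the rest of compound 2 and exchanges one group: pyrimidin-4-yl in place of 3-methoxypyridin-2-yl on a nitrogen on an aromatic ring. Among the compounds with values here, no measured pair covers this exchange, so the expectation rests on little. Compound 1, which has no 3-methoxypyridin-2-yl group, stands at 61%, and a fall rather than a rise is therefore expected. The expected change, probably just beyond the scatter, is a number 13 percentage points lower from compound 2 to compound 3 (beyond the scatter). For compound 3 the estimated value is 70%, with an expected range of 52% to 85%.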

Compound 3, percent of the compound remaining: 88%
Compound 3: the middle estimate sits 18 percentage points below what was measured; measured number above the stated range.
By their numbers in this assay, from the lowest: compound 1; then compounds 2 and 3 (each within the scatter of the next).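

In this assay, pyrimidin-4-yl in place of 3-methoxypyridin-2-yl on a nitrogen on an aromatic ring gives a number 5 percentage points higher from compound 2 to compound 3 (within the scatter), so the two groups cannot be told apart at this position. Within the data shown here, this is the first step that can be read here, and with compound 3 at 88% in this read-out, the 3-methoxypyridin-2-yl group is not needed for a value of this size. Nothing at hand explains why the two groups read alike.

From the compounds shown here alone, whether this position also tolerates a non-aromatic group on the same nitrogen, such as morpholine or a short alkyl chain, stays open. Also open, going by these compounds, is whether the same exchange reads alike when a trifluoromethoxy group replaces the trifluoromethyl group on the other aryl ring.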